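Acetal-linked thymine esters: shortening the acyl group

The source may hold more compounds than are shown below. What is called first, only, known or untested is meant among the compounds shown, and "the series" means these compounds.

The series shares a core carrying an ester on the side chain; compound 1 `Cc1cn([C@H]2CO[C@@H](COC(=O)C3CCCCC3)O2)c(=O)[nH]c1=O` bears a cyclohexyl group on the carbonyl carbon, compound 2 `CCCCCCCCCCCCCCCC(=O)OC[C@@H]1OC[C@H](n2cc(C)c(=O)[nH]c2=O)O1` a long saturated chain, compound 3 `CCCCCCCCCCCC(=O)OC[C@@H]1OC[C@H](n2cc(C)c(=O)[nH]c2=O)O1` a chain shorter by four carbons. In a physicochemical assay for metabolic stability, at pH 8, in the presence of a further agent that is not named here (on this read-out higher numbers stand for a longer-lived compound and lower numbers for a shorter-lived compound), compound 1 gives 0.322 h, compound 2 gives 0.8 h and compound 3 gives 0.683 h. Compound 1 therefore stands lowest of the three, beyond the scatter from both others. Among the compounds with values here, the only step measured within the set, a 1.2-fold lower number from compound 2 to compound 3 (0.07 log units; within the scatter), concerns a saturated chain far from the carbonyl and is within the scatter.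

Compound 4 `CC(=O)OC[C@@H]1OC[C@H](n2cc(C)c(=O)[nH]c2=O)O1` differs from compound 1 by methyl in place of cyclohexyl on a carbonyl carbon. Within the data shown here, no measured step touches the group on the carbonyl carbon itself, so the shortening of the chain in compound 2 to compound 3 bears only loosely on it. In this assay compound 4 is expected to sit close to compound 1, with a 1.3-fold lower number from compound 1 to compound 4 (0.11 log units; within the scatter) as the estimated step, if anything a slightly lower number. The estimate for compound 4 is 0.25 h, within 0.1 h to 0.6 h.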

Compound 4, half-life: 0.272 h
For compound 4 the middle estimate is 1.1-fold (0.04 log units) below the measured one, and the stated range covers the measured number.
By their numbers in this assay, from the lowest: compounds 4 and 1 (each within the scatter of the next); then compounds 3 and 2 (each within the scatter of the next).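

In this assay, the first change made on the carbonyl carbon itself, methyl in place of cyclohexyl, gives a 1.2-fold lower number from compound 1 to compound 4 (0.07 log units; within the scatter) and so stays within the scatter. At this position, going from a ring of 6 heavy atoms to a single carbon does not separate compound 1 from compound 4, and the two form one low pair, set apart from the pair of compound 3 and compound 2. Nothing measured explains why the numbers fall into these two pairs.

Still open, going by these compounds, is where the numbers start to part between methyl and the long saturated chains, for instance with a hexyl chain on the carbonyl carbon. Also open, on these data alone, is whether a phenyl group or a chain ending in an amine or a carboxylic acid at that position would give a step beyond the scatter.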